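Ethyl(methyl)carbamoyl in Place of Carbamoyl on the Shared Core

The source may hold more compounds than are shown below. What is called first, only, known or untested is meant among the compounds shown, and "the series" means these compounds.

Compound 1 `CCNC(=O)N1CCN(C(=S)SCc2cn(Cc3ccccc3F)nn2)CC1`: 23700 nM
Compound 2 `COc1cc(Cn2cc(CSC(=S)N3CCN(C(N)=O)CC3)nn2)cc(OC)c1OC`: > 128000 nM

Of the compounds shown here, two have been measured in a functional assay on EC9706 cells (Homo sapiens) for cytotoxicity, read by MTT assay, with a stated time of 72 h; a lower number here means a stronger inhibitor, a higher number a weaker inhibitor. Compound 1 gives 23700 nM. Compound 2 reaches only a limit of the assay, > 128000 nM, so no number stands for it; it sits at the limit of > 128000 nM in this assay, at which 1 of the 2 values shown sits. Compound 3 `CCN(C)C(=O)N1CCN(C(=S)SCc2cn(Cc3cc(OC)c(OC)c(OC)c3)nn2)CC1` keeps the trimethoxybenzyl portion of compound 2 and differs from it by ethyl(methyl)amino in place of amino on a carbonyl carbon. Among the measured compounds shown here, no step between two measured compounds is known here, and compound 1 and compound 2 differ in more than one place, so their values show only that compound 1 has a number while compound 2 has none. Against a bare limit, a step from compound 2 to compound 3 in this assay is expected to be small, within the scatter, with a real chance of another limit. Compound 3 is estimated at 90000 nM, between 30000 nM and 200000 nM. That expected step is an at least 1.4-fold lower number from compound 2 to compound 3 (0.15 log units; that floor lies within the scatter).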

Compound 3, half-maximal inhibitory concentration: > 128000 nM
Compound 3 gave a limit, no number; the forecaster's own chance of this, stated with the estimate: 50%; at least 1.4-fold (0.15 log units) between middle value and limit.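

Compound 3, like compound 2, gives only a limit and no number, so no step between compound 2 and compound 3 can be read: the limit of > 128000 nM in this assay, at which 2 of the 3 values shown sit.

The compounds shown leave open whether ethyl(methyl)carbamoyl in place of carbamoyl changes the value at all.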